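Replacing fluoromethyl with diisopropylcarbamoyl on the enone ring carbon

The source may hold more compounds than are shown below. What is called first, only, known or untested is meant among the compounds shown, and "the series" means these compounds.

Compound 1 `CC(C)=CCC[C@]1(C)/C=C/[C@@H](OC(=O)C=C(C)C)[C@](C)(O)/C=C/C(=O)/C(CF)=C\C1` gives 240 nM in a functional assay on MCF7 cells (Homo sapiens) for antiproliferative activity, read by MTT assay, with a stated time of 48 h (on this read-out lower numbers stand for stronger inhibition and higher numbers for weaker inhibition), the lowest of the three numbers available. Compound 3 `CC(C)=CCC[C@](C)(/C=C/[C@@H](OC(=O)C=C(C)C)[C@](C)(O)/C=C/C(=O)/C=C/N1CCN(C)CC1)CC=O` gives 8840 nM in this assay, and compound 2 `CC(C)=CCC[C@]1(C)/C=C/[C@@H](OC(=O)C=C(C)C)[C@](C)(O)/C=C/[C@H](O)/C(CO)=C\C1` gives 33000 nM, both beyond the scatter above compound 1. Compound 4 `CC(C)=CCC[C@]1(C)/C=C/[C@@H](OC(=O)C=C(C)C)[C@](C)(O)/C=C/C(=O)/C(C(=O)N(C(C)C)C(C)C)=C\C1` has not been measured. It differs from compound 1 by diisopropylcarbamoyl in place of fluoromethyl on a double-bonded ring carbon. Among the measured compounds shown here, no measured pair shows this kind of change, so the size of the step is uncertain; the account expects a moderate rise in the number, beyond the scatter, toward weaker inhibition. In this assay compound 4 is estimated at 1500 nM, in a range of 300 nM to 8000 nM, which would be a step of a 6.3-fold higher number from compound 1 to compound 4 (0.80 log units; beyond the scatter).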

Compound 4, half-maximal inhibitory concentration: 17200 nM
The estimate for compound 4 lay 11-fold (1.06 log units) below the measured number, and the stated range ends below it.
By their numbers in this assay, from the lowest: compound 1; then compounds 3, 4 and 2 (each within the scatter of the next, the first and the last beyond it).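

In this assay, among the compounds shown here, diisopropylcarbamoyl in place of fluoromethyl on the double-bonded ring carbon gives a 72-fold higher number from compound 1 to compound 4 (1.86 log units; beyond the scatter), toward weaker inhibition, and this is the first step read at this position. It shows that the number responds strongly to what this ring carbon carries, with the rest of the core of compound 1 unchanged. Nothing available accounts for the size of this step. The compounds shown leave open how a dimethylcarbamoyl group, a carboxylic acid or a plain methyl on this carbon would stand. They also leave open whether the rise goes with the carbamoyl group itself or with its two isopropyl groups.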